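The source may hold more compounds than are shown below. What is called first, only, known or untested is meant among the compounds shown, and "the series" means these compounds.

Compound 1 `Cc1cc(Nc2cc(-c3ccccc3)[nH]n2)n2nc(SCc3csc4ccccc34)nc2n1` gives 4420 nM in a functional assay on PC-9 cells (Homo sapiens) for inhibition, read by MTT assay, with a stated time of 72 h; on this read-out higher numbers stand for weaker inhibition and lower numbers for stronger inhibition. Going by the values given here, compound 2 `Cc1cc(Nc2cc(-c3ccccc3)[nH]n2)n2nc(SCc3ccc(Cl)cc3)nc2n1` gives 6710 nM in this assay, and the only measured step, a 1.5-fold higher number from compound 1 to compound 2 (0.18 log units; within the scatter), lies within the scatter. Compound 3 `Cc1cc(Nc2ccn(Cc3nc(C)c4ccccc4n3)n2)n2nc(SCc3ccc(Br)cc3)nc2n1` gives 5450 nM in this assay; it stands second highest of the three numbers, within the scatter of both compound 2 and compound 1.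

Compound 4 `Cc1cc(Nc2ccn(Cc3ccc(C(F)(F)F)cc3)n2)n2nc(SCc3ccc(Br)cc3)nc2n1` has not yet been measured. It differs from compound 3 by 4-(trifluoromethyl)phenyl in place of 4-methylquinazolin-2-yl on a saturated chain carbon bound to an aromatic nitrogen. Among the compounds with values here, the single measured step, a 1.5-fold higher number from compound 1 to compound 2 (0.18 log units; within the scatter), concerns the saturated chain carbon bound to a sulfur, a different place, so no measured step bears on a change at the carbon bound to an aromatic nitrogen. Compound 4 is therefore expected to show a step of a 1.0-fold lower number from compound 3 to compound 4 (0.00 log units; within the scatter) in this assay, none beyond the scatter. The estimate for compound 4 is 5400 nM, ranging from 2500 nM to 12000 nM.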

Compound 4, half-maximal inhibitory concentration: 5580 nM
Beside the measured number, compound 4's estimate is 1.0-fold (0.01 log units) below it; the measured number falls inside the stated range.
By their numbers in this assay, from the lowest: compounds 1, 3, 4 and 2 (each within the scatter of the next).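

Going by these compounds alone, at the saturated chain carbon bound to an aromatic nitrogen, 4-(trifluoromethyl)phenyl in place of 4-methylquinazolin-2-yl gives a 1.0-fold higher number from compound 3 to compound 4 (0.01 log units; within the scatter) in this assay, the first measured step at this place. The exchange removes the six-membered aromatic ring with 2 hetero atoms and both hydrogen-bond acceptors of the leaving group, yet the step stays within the scatter. No measured evidence explains this result. On these data alone, whether an amine or a carboxylic acid at this place would stay within the scatter remains open. So does whether a simple methyl group would.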